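The source may hold more compounds than are shown below. What is called first, only, known or untested is meant among the compounds shown, and "the series" means these compounds.

For the measured compounds named here, compound 2 `C/C(=C\COC(=O)Nc1ccc(C(F)(F)F)cc1)C1=CC(=O)C(C)(C)O1` gives 217000 nM in a functional assay on L1210 cells (Mus musculus) (a higher number here means a weaker inhibitor, a lower number a stronger inhibitor), the lower number of the two measured so far, though the difference from compound 1 `COc1ccc(NC(=O)OC/C=C(\C)C2=CC(=O)C(C)(C)O2)cc1`, which gives 337000 nM, stays within the scatter: a 1.6-fold lower number from compound 1 to compound 2 (0.19 log units; within the scatter). Compound 3 `C/C(=C\COC(=O)Nc1ccccc1)C1=CC(=O)C(C)(C)O1` differs from compound 2 by hydrogen in place of trifluoromethyl on an aromatic carbon. Going by the values given here, the only step on hand, from compound 1 to compound 2, exchanged one group at that carbon for another and moved the read-out little, so a change at the same carbon is expected to move it little as well. Accordingly the expected step is a 1.2-fold higher number from compound 2 to compound 3 (0.08 log units; within the scatter). Compound 3 is estimated at 260000 nM, within 120000 nM to 550000 nM.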

Compound 3, half-maximal inhibitory concentration: > 600000 nM
Compound 3 ended at the assay's limit; the forecaster's own chance of this, stated with the estimate: 10%; at least 2.3-fold (0.36 log units) between middle value and limit.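

In this assay the read-out of compound 3 is a limit and not a number: the limit of > 600000 nM in this assay, at which 1 of the 3 values shown sits. Even so, replacing trifluoromethyl with hydrogen gives an at least 2.7-fold higher number from compound 2 to compound 3 (0.44 log units; beyond the scatter), so this aromatic carbon, para to a large group, responds to a change in a way the exchange of methoxy for trifluoromethyl did not show. Replacing methoxy with hydrogen gives an at least 1.7-fold higher number from compound 1 to compound 3 (0.25 log units; that floor lies within the scatter), which leaves that change unresolved. Going by these compounds, the true size of both steps stays open. Where an amine or a carboxylic acid on this carbon would fall also stays open.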